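Swapping Methyl for Methoxy on a Shared Core

A few compounds are considered here, and "the series" means these few. Any claim that something is new, unique, unknown or untested is made for them only; others in the source may bear on it.

Of the compounds shown here, three with one shared core have been tested in a functional assay on MDA-MB-231 cells (Homo sapiens) for antiproliferative activity, read by MTT assay, with a stated time of 48 h; on this read-out higher numbers stand for weaker inhibition and lower numbers for stronger inhibition. Compound 1 `COc1ccc2nc(Nc3ccnc(Nc4ccc(S(N)(=O)=O)cc4)n3)sc2c1` gives 6240 nM. Compound 2 `NS(=O)(=O)c1ccc(Nc2ncc(F)c(Nc3nc4ccc(Cl)cc4s3)n2)cc1` gives 2790 nM in this assay. Compound 3 `Cc1ccc2nc(Nc3nc(Nc4ccc(S(N)(=O)=O)cc4)ncc3F)sc2c1` gives 6390 nM in this assay, the highest of the three numbers; its gap to compound 1 lies within the scatter, while its gap to compound 2 lies beyond it. Among the measured compounds shown here, the single one-place step measured so far is a 2.3-fold higher number from compound 2 to compound 3 (0.36 log units; beyond the scatter).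

Compound 4 `COc1ccc2nc(Nc3nc(Nc4ccc(S(N)(=O)=O)cc4)ncc3F)sc2c1` has not yet been measured. (methoxy in place of methyl on an aromatic carbon). For the measured compounds named here, no measured step exchanges methyl for methoxy, so the one known step does not bear directly on this change. Compound 1 carries the same methoxy group and gives 6240 nM in this assay. Compound 3 gives 6390 nM in this assay, and these two numbers lie within the scatter of each other. The step is therefore expected to be a 1.1-fold lower number from compound 3 to compound 4 (0.04 log units; within the scatter), none beyond the scatter. Compound 4 is estimated at 5800 nM, with a range from 2600 nM to 13000 nM.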

Compound 4, half-maximal inhibitory concentration: 26600 nM
Compound 4: middle estimate off by 4.6-fold (0.66 log units), on the low side, outside the stated range (above it).
By their numbers in this assay, from the lowest: compound 2; then compounds 1 and 3 (each within the scatter of the next); then compound 4.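

In this assay, the group at this place on the shared core matters more than compounds 1 to 3 could show: methoxy in place of methyl is not a neutral swap here (a 4.2-fold higher number from compound 3 to compound 4 (0.62 log units; beyond the scatter)). Methoxy in place of chloro at the same place gives a larger step (a 9.5-fold higher number from compound 2 to compound 4 (0.98 log units; beyond the scatter)), so among chloro, methyl and methoxy the numbers rise in that order, each step beyond the scatter. The other change also counts, since with methoxy held fixed, fluoro in place of hydrogen gives a higher number (a 4.3-fold higher number from compound 1 to compound 4 (0.63 log units; beyond the scatter)), though no measurement on hand gives a reason for any of these steps.

The compounds shown leave open whether fluoro in place of hydrogen gives the same step alongside chloro or methyl. From the compounds shown here alone, how a hydroxy group or an amine would compare at this place also remains unknown.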